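Hydroxycyclopentyl Thioether in Place of a Dimethylaminopropyl Chain

This account rests on a few compounds, and the source may have more. Where it says the series, first, only, none or still open, it means among the compounds named here.

For the measured compounds named here, compound 3 `CC(C)c1n[nH]c2c(NCc3ccc(-c4ccccn4)cc3)nc(SCCCN(C)C)nc12` gives 105 nM in a functional assay on HT cells (Homo sapiens) for antiproliferative activity, read by fluorescence, with a stated time of 72 h (a higher number here means a weaker inhibitor of growth, a lower number a stronger inhibitor of growth), the second highest of the three numbers measured so far. Compound 2 `CC(O)CSc1nc(NCc2ccc(-c3ccccn3)cc2)c2[nH]nc(C(C)C)c2n1` gives 62 nM and compound 1 `CC(C)c1n[nH]c2c(NCc3ccc(-c4ccccn4)cc3)nc(SCC(O)C(F)(F)F)nc12` gives 690 nM; a 1.7-fold higher number from compound 2 to compound 3 (0.23 log units; within the scatter), while a 6.6-fold lower number from compound 1 to compound 3 (0.82 log units; beyond the scatter). Compound 4 `CC(C)c1n[nH]c2c(NCc3ccc(-c4ccccn4)cc3)nc(SC3CCCC3O)nc12` carries 2-hydroxycyclopentyl in place of 3-(dimethylamino)propyl on a sulfur. The step that bears most directly, a 1.7-fold higher number from compound 2 to compound 3 (0.23 log units; within the scatter), shows that swapping a hydroxy-bearing chain for a dimethylamino chain on the sulfur stayed within the scatter, and the large step of an 11-fold lower number from compound 1 to compound 2 (1.05 log units; beyond the scatter) concerns a trifluoromethyl that neither compound 3 nor compound 4 contains. A step of a 1.3-fold lower number from compound 3 to compound 4 (0.12 log units; within the scatter) is therefore expected, small in either direction. Compound 4 is estimated at 80 nM, with a range from 30 nM to 250 nM.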

Compound 4, concentration for 50% growth inhibition: 567 nM
For compound 4 the middle estimate is 7.1-fold (0.85 log units) below the measured one, outside the stated range (above it).
By their numbers in this assay, from the lowest: compounds 2 and 3 (each within the scatter of the next); then compounds 4 and 1 (each within the scatter of the next).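

In this assay, a hydroxyl on the group on the sulfur does not by itself keep the number low: closing the chain into 2-hydroxycyclopentyl in place of 2-hydroxypropyl gives a clear loss (a 9.1-fold higher number from compound 2 to compound 4 (0.96 log units; beyond the scatter)). The same ring also loses against 3-(dimethylamino)propyl (a 5.4-fold higher number from compound 3 to compound 4 (0.73 log units; beyond the scatter)) and stays level with 3,3,3-trifluoro-2-hydroxypropyl (a 1.2-fold lower number from compound 1 to compound 4 (0.09 log units; within the scatter)), so two quite different groups here end up within the scatter of each other. Nothing measured here explains these steps. From the compounds shown here alone, what a plain cyclopentyl or a 2-aminocyclopentyl on the sulfur would give remains open.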